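This account rests on a few compounds, and the source may have more. Where it says the series, first, only, none or still open, it means among the compounds named here.

Measured so far in a functional assay on MCF7 cells (Homo sapiens) for inhibition, read by MTT assay, with a stated time of 48 h; a lower number here means a stronger inhibitor, a higher number a weaker inhibitor
- Compound 1 `COc1cc(/C=N/NC(=O)COc2ccc3c(-c4ccccc4)cc(=O)oc3c2)cc(OC)c1OC` gives 4.3 ug/mL
- Compound 2 `CCn1c(C)cs/c1=N\NC(=O)COc1ccc2c(-c3ccccc3)cc(=O)oc2c1` gives 78 ug/mL

Compound 2 holds the higher of the two numbers, beyond the scatter from compound 1, and so is the weaker inhibitor of the pair. Compound 3 `CCn1c(C)c(C(C)=O)s/c1=N\NC(=O)COc1ccc2c(-c3ccccc3)cc(=O)oc2c1` departs from compound 2 by acetyl in place of hydrogen on an aromatic carbon. Among the measured compounds shown here, no measured step covers this change, so the expectation is loose: a moderate move toward a lower number in this assay that may not clear the scatter by much. The expected change is a 2.6-fold lower number from compound 2 to compound 3 (0.41 log units; beyond the scatter) on this rough estimate. Compound 3 is estimated at 30 ug/mL (expected range 7 ug/mL to 120 ug/mL)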

Compound 3, half-maximal inhibitory concentration: 28 ug/mL
Compound 3: middle estimate off by 1.1-fold (0.03 log units), on the high side; the measured number falls inside the stated range.
By their numbers in this assay, from the lowest: compound 1; then compound 3; then compound 2.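

In this assay, acetyl in place of hydrogen on the aromatic carbon next to the ring sulfur gives a 2.8-fold lower number from compound 2 to compound 3 (0.44 log units; beyond the scatter), a modest move toward stronger inhibition. This position therefore tolerates acetyl, and the change on this ring alone moves the number beyond the scatter. No measured evidence bears on the origin of this step.

Open, from the compounds shown here alone, is whether a carboxylic acid, an amine or a longer acyl chain on this carbon would move the number further, or reverse it. Also open, going by these compounds, is whether the step holds with a group other than ethyl on the ring nitrogen.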